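The source may hold more compounds than are shown below. What is called first, only, known or untested is meant among the compounds shown, and "the series" means these compounds.

Working notes on a short series sharing one core. In an ADME assay on MT4 cells (Homo sapiens) for cytotoxicity, read by MTT assay, with a stated time of 5 days (on this read-out lower numbers stand for higher toxicity in this test and higher numbers for lower toxicity in this test), compound 1 `Cc1cc(C#N)cc(C)c1Oc1nc(NC2CCCN(Cc3ccc(C(N)=O)cc3)C2)nc2ccsc12` gives 19500 nM, compound 2 `Cc1cc(C#N)cc(C)c1Oc1nc(NC2CCC(NCc3cccc(C(N)=O)c3)CC2)nc2ccsc12` gives 9210 nM and compound 3 `Cc1cc(C#N)cc(C)c1Oc1nc(NC2CCC(NCc3ccc([N+](=O)[O-])cc3)CC2)nc2ccsc12` gives 54400 nM. Compound 2 holds the lowest of these three numbers, with compound 1 nearest to it and compound 3 furthest away. The next structure is compound 4 `Cc1cc(C#N)cc(C)c1Oc1nc(NC2CCC(NCc3ccccc3)CC2)nc2ccsc12`, whose difference from compound 2 is hydrogen in place of carbamoyl on an aromatic carbon. Within the data shown here, only one measured step bears on this change, a 5.9-fold higher number from compound 2 to compound 3 (0.77 log units; beyond the scatter), with 4-nitrophenyl in place of 3-carbamoylphenyl. That step also removes the carbamoyl but brings in a new group, so it is an indirect guide. Among the measured compounds shown here, no measured pair isolates the loss of carbamoyl. A move to a higher number in this assay is expected, smaller than that step and possibly not clear of the scatter. The expected change is a 2.2-fold higher number from compound 2 to compound 4 (0.34 log units; beyond the scatter). For compound 4 the estimate is 20000 nM, with an expected range from 8000 nM to 50000 nM.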

Compound 4, half-maximal cytotoxic concentration: 2970 nM
The estimate for compound 4 lay 6.7-fold (0.83 log units) above the measured number; the measured number lies below the stated range.
By their numbers in this assay, from the lowest: compound 4; then compound 2; then compound 1; then compound 3.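

In this assay, hydrogen in place of carbamoyl on this aromatic carbon gives a 3.1-fold lower number from compound 2 to compound 4 (0.49 log units; beyond the scatter), so removing the carbamoyl alone moves the number down, not up. Hydrogen in place of nitro gives an 18-fold lower number from compound 3 to compound 4 (1.26 log units; beyond the scatter), which places the unsubstituted benzylamino compound below both substituted ones and makes the direction of the step depend on neither group being simply absent. No measurement at hand gives a reason for these steps.

On these data alone, whether a carboxylic acid, an amine or a methoxy group on the ring also gives a higher number than hydrogen remains open. The two substituted compounds compare 3-carbamoylphenyl with 4-nitrophenyl, so the identity of the group and its place on the ring are not separated.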